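Methoxy added to the styryl ring of the sulfone series

The source may hold more compounds than are shown below. What is called first, only, known or untested is meant among the compounds shown, and "the series" means these compounds.

Measured so far in a functional assay on BT-20 cells (Homo sapiens) for antiproliferative activity, read by trypan blue exclusion; a lower number here means a stronger inhibitor, a higher number a weaker inhibitor:
- compound 2 `COc1ccc(CS(=O)(=O)/C=C/c2ccccc2OC)cc1`: 5000 nM
- compound 3 `COc1ccc(CS(=O)(=O)/C=C/c2ccc(F)cc2OC)cc1`: 15000 nM
- compound 1 `COc1ccc(/C=C/S(=O)(=O)Cc2ccc(OC)cc2)cc1`: > 20000 nM (a limit of this assay, not a number)

Compound 2 has the lowest of the two numbers in this assay, with compound 3 the nearest. For compound 1 only a limit is reported, (the limit of > 20000 nM in this assay, at which 1 of the 3 values shown sits). Among the measured compounds shown here, the one single-point step seen is a 3.0-fold higher number from compound 2 to compound 3 (0.48 log units; beyond the scatter), a fluoro in place of hydrogen on an aromatic carbon of the styryl ring.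

Compound 4 `COc1ccc(CS(=O)(=O)/C=C/c2c(OC)cccc2OC)cc1` differs from compound 2 as follows: methoxy in place of hydrogen on an aromatic carbon. For the measured compounds named here, no measured step puts a second methoxy on this ring; the fluoro step from compound 2 to compound 3 is the only change made on the same ring, and it raised the number modestly. On that basis a modest rise is expected, a 1.6-fold higher number from compound 2 to compound 4 (0.20 log units; within the scatter), with wide uncertainty in either direction. Compound 4 is therefore estimated at 8000 nM, between 3000 nM and 25000 nM, with some chance that only a limit is returned.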

Compound 4, half-maximal inhibitory concentration: 400 nM
For compound 4 the middle estimate is 20-fold (1.30 log units) above the measured one, and the stated range ends above it.
By their numbers in this assay, from the lowest: compound 4; then compound 2; then compound 3. At a limit, above all of these: compound 1.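

The added methoxy, ortho to a large group and meta to a methoxy group, gives a 13-fold lower number from compound 2 to compound 4 (1.10 log units; beyond the scatter) in this assay, so a substituent on the styryl ring of this series can lower the number substantially. Among the compounds shown here, the only other step on this ring, a 3.0-fold higher number from compound 2 to compound 3 (0.48 log units; beyond the scatter), runs the opposite way, so the direction of change on this ring is not fixed; because those steps differ in both group and place, the two factors cannot be separated from them. No measurement shown gives a reason for the size of the methoxy step.

Going by these compounds, whether an amine, a hydroxyl group or a longer alkoxy chain at this position would also lower the number remains open. Also open, on these data alone, is whether the methoxy gain depends on the methoxy group already on this ring.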